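The source may report more compounds than this note shows. Statements on the series, on what has been measured and on what is new or still open speak of the compounds shown alone.

Of the compounds shown here, three sharing one core have been tested in a functional assay on HT-29 cells (Homo sapiens) for inhibition, read by CellTiter-Glo, with a stated time of 72 h (a lower number here means that less compound is tolerated, a higher number that more compound is tolerated), and they differ from one another only in the group attached to the carbonyl carbon of the amide. Compound 1 `CC1=C(C(C)C(=O)N(C)CCN(C)C)c2cc(F)ccc2/C1=C\c1ccc([S+](C)[O-])cc1` gives 11900 nM in this assay. Compound 2 `CC1=C(C(C)C(=O)N(CCNC(C)C)C(C)C)c2cc(F)ccc2/C1=C\c1ccc([S+](C)[O-])cc1` gives 8060 nM, and compound 3 `CC1=C(C(C)C(=O)NCCN2CCCCC2)c2cc(F)ccc2/C1=C\c1ccc([S+](C)[O-])cc1` gives 9670 nM. The swaps among these three amide groups have made little difference: a 1.5-fold lower number from compound 1 to compound 2 (0.17 log units; within the scatter), a 1.2-fold lower number from compound 1 to compound 3 (0.09 log units; within the scatter), and a 1.2-fold higher number from compound 2 to compound 3 (0.08 log units; within the scatter). Compound 3 therefore sits within the scatter of both of its neighbours, with compound 2 the closer of the two and compound 1 the further, and none of the three can be called more or less tolerated than the others.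

Compound 4 `CC1=C(C(C)C(=O)N2CCN(CCCN(C)C)CC2)c2cc(F)ccc2/C1=C\c1ccc([S+](C)[O-])cc1` is the next variation on the same amide position: 4-(3-(dimethylamino)propyl)piperazin-1-yl in place of (2-(piperidin-1-yl)ethyl)amino on a carbonyl carbon. The three measured steps are the ones that bear on this, since each of them also exchanges one amine-bearing side group for another at this carbonyl carbon, and each stayed within the scatter. On that basis no step beyond the scatter is expected in this assay, and compound 4 is estimated to land close to compound 3, giving an expected 1.0-fold lower number from compound 3 to compound 4 (0.01 log units; within the scatter). The estimate for compound 4 is 9500 nM, with a range from 4000 nM to 22000 nM.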

Compound 4, half-maximal cytotoxic concentration: 32000 nM
Compound 4: middle estimate off by 3.4-fold (0.53 log units), on the low side; measured number outside the range, above it.
By their numbers in this assay, from the lowest: compounds 2, 3 and 1 (each within the scatter of the next); then compound 4.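

Within the data shown here, the amide position is not indifferent to what sits on the carbonyl carbon: in this assay, the 4-(3-(dimethylamino)propyl)piperazin-1-yl group gives the first steps beyond the scatter, with a 3.3-fold higher number from compound 3 to compound 4 (0.52 log units; beyond the scatter), a 4.0-fold higher number from compound 2 to compound 4 (0.60 log units; beyond the scatter) and a 2.7-fold higher number from compound 1 to compound 4 (0.43 log units; beyond the scatter), so compound 4 is the most tolerated of the four. Losing the amide hydrogen is not enough to account for this pattern, since compound 1 and compound 2 also lack it and still stay within the scatter of compound 3. No measurement shown here accounts for the step.

The new group differs from the old in several ways at once, including its piperazine ring and its dimethylaminopropyl chain, so the compounds shown leave open which feature goes with the higher number. A simple 4-methylpiperazin-1-yl group would test the ring without the chain, while a morpholine ring on the same carbonyl carbon would test whether the second ring nitrogen matters at all.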